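The compounds below may be only part of what the source reports. "The series", "measured", "known", "first", "only" and "open" are said of these compounds alone.

Compound 1 `CC(=O)OC[C@H]1O[C@@H](n2c(SCc3cc4ccccc4oc3=O)nc3cncnc32)[C@H](OC(C)=O)[C@@H]1OC(C)=O` gives 39000 nM in a functional assay on Huh-5-2 cells (Homo sapiens) for cytotoxicity, read by microscopy; on this read-out higher numbers stand for lower toxicity in this test and lower numbers for higher toxicity in this test. Compound 2 `COc1cccc2cc(CSc3nc4cncnc4n3[C@@H]3O[C@H](COC(C)=O)[C@@H](OC(C)=O)[C@H]3OC(C)=O)c(=O)oc12` gives 7500 nM in this assay; the step of a 5.2-fold lower number from compound 1 to compound 2 (0.72 log units; beyond the scatter) follows the change (methoxy in place of hydrogen on an aromatic carbon). Compound 3 `CC(=O)OC[C@H]1O[C@@H](n2c(SCc3cc4ccccc4oc3=O)nc3cncnc32)[C@H](O)[C@@H]1O` gives 8700 nM in this assay; the difference between its core and the core of compound 1 is not broken down here, and the two values lie apart beyond the scatter. Compound 4 `COc1cccc2cc(CSc3nc4cncnc4n3[C@@H]3O[C@H](COC(C)=O)[C@@H](O)[C@H]3O)c(=O)oc12` carries the same change on the core of compound 3: methoxy in place of hydrogen on an aromatic carbon. A lower number is expected, a 3.1-fold lower number from compound 3 to compound 4 (0.49 log units; beyond the scatter), because the earlier step of a 5.2-fold lower number from compound 1 to compound 2 (0.72 log units; beyond the scatter) went that way; that step stands alone, so the expectation is held somewhat short of it. For compound 4 the expected value in this assay is 2800 nM, with a likely range from 1100 nM to 8000 nM.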

Compound 4, half-maximal cytotoxic concentration: 11000 nM
Beside the measured number, compound 4's estimate is 3.9-fold (0.59 log units) below it, outside the stated range (above it).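

In this assay, methoxy in place of hydrogen on an aromatic carbon does not carry over unchanged from one core to the other: the same change on two cores in this assay, a 5.2-fold lower number (0.72 log units; beyond the scatter) from compound 1 to compound 2 and a 1.3-fold higher number (0.10 log units; within the scatter) from compound 3 to compound 4, 6.6-fold (0.82 log units) apart, beyond the scatter of two such steps. On the core of compound 3 the change gives a 1.3-fold higher number from compound 3 to compound 4 (0.10 log units; within the scatter), so the lower number seen on the core of compound 1 cannot be read as a general effect of this change in the series. These two pairs do not show which feature of the cores sets the steps apart, nor how the change would behave on a third core.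

Open, as far as these compounds go, is whether an ethoxy group, a fluorine or an amine on the same aromatic carbon would follow either step. Also open, from the compounds shown here alone, is which of the two steps a further core would resemble.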